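This account rests on a few compounds, and the source may have more. Where it says the series, first, only, none or still open, it means among the compounds named here.

Compound 3 `Nc1nc(N)c(-c2ccc(NCc3ccc([N+](=O)[O-])cc3)cc2)c(COCc2ccccc2)n1` gives 5.8 nM in a functional assay on CHOK cells for antagonist activity at growth hormone secretagogue receptor type 1 (Homo sapiens), read by calcium flux (on this read-out lower numbers stand for stronger inhibition and higher numbers for weaker inhibition), the lowest number among the three measured compounds. Compound 1 `CCc1nc(N)nc(N)c1-c1ccc(NCc2ccc(S(C)(=O)=O)cc2)cc1` gives 12 nM in this assay, and compound 2 `CCc1nc(N)nc(N)c1-c1ccc(NCc2cc(F)c(S(=O)(=O)C(F)(F)F)c(F)c2)cc1` gives 690 nM; both stand beyond the usual scatter from compound 3, so compound 3 is the most potent of the three. The two values of compound 1 and compound 2 differ only in the group carried on the benzylamine, and they show that this part of the molecule can shift the number a long way.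

Compound 4 `CC(C)(C)CNc1ccc(-c2c(N)nc(N)nc2COCc2ccccc2)cc1` keeps the core of compound 3 and changes the benzylamine end: tert-butyl in place of 4-nitrophenyl on a saturated chain carbon bound to a nitrogen on an aromatic ring. The aromatic ring with its nitro group is gone, and a small branched saturated group takes its place. Going by the values given here, no measured pair shows this kind of change, so the direction has to be judged from the fact that every measured compound carries an aromatic ring at this position and that compound 1 and compound 2 differ widely there. A weaker result than compound 3 is expected, by a moderate step beyond the scatter, a 10-fold higher number from compound 3 to compound 4 (1.01 log units; beyond the scatter). Compound 4 is therefore estimated at 60 nM, with a range from 12 nM to 300 nM.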

Compound 4, half-maximal inhibitory concentration: 700 nM
Estimate against measurement, compound 4: 12-fold (1.07 log units) below, and the stated range ends below it.
By their numbers in this assay, from the lowest: compound 3; then compound 1; then compounds 2 and 4 (each within the scatter of the next).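

In this assay, going by these compounds alone, exchanging 4-nitrophenyl for tert-butyl gives a 120-fold higher number from compound 3 to compound 4 (2.08 log units; beyond the scatter) and is the first step here between two compounds that differ in one place. With the rest of the molecule held constant, this change alone moves the number by a large step, so the group at this position has a strong effect on the read-out, and here 4-nitrophenyl gives much the stronger inhibition. The compounds shown offer no independent measurement that accounts for the size of this step.

The step removes the aromatic ring and the nitro group together, so it leaves open whether the loss follows from losing the ring, the nitro group or both. Compounds carrying unsubstituted phenyl at this place would separate the ring from the nitro group, while cyclohexyl would show how a saturated ring compares with both the aromatic ring and the open-chain tert-butyl.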